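Swapping a Pentylphenyl Arm for a Difluorophenyl Arm

This account rests on a few compounds, and the source may have more. Where it says the series, first, only, none or still open, it means among the compounds named here.

Compound 1 `CCCCCc1ccc(-c2cn(C[C@H](O)[C@H]3OC(=O)C(OCc4ccccc4)=C3OCc3ccccc3)nn2)cc1`: 8390 nM
Compound 2 `O=C1O/C(=C\Cn2cc(-c3cc(C(F)(F)F)cc(C(F)(F)F)c3)nn2)C(OCc2ccccc2)=C1OCc1ccccc1`: > 100000 nM, a limit of the assay
Compound 3 `COc1ccc(-c2cn(C/C=C3\OC(=O)C(OCc4ccccc4)=C3OCc3ccccc3)nn2)cc1`: > 100000 nM, a limit of the assay

Among the compounds with values here, in a functional assay on HeLa cells (Homo sapiens) for antiproliferative activity, read by MTT assay, with a stated time of 72 h (a lower number here means a stronger inhibitor, a higher number a weaker inhibitor), compound 1 gives 8390 nM, the only measured number here. Compound 2 reaches only the limit > 100000 nM. Compound 3 likewise stops at the limit > 100000 nM. So compound 1 stands alone among the three, with the limit of > 100000 nM in this assay, at which 2 of the 3 values shown sit, the only comparison available.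

Compound 4 `O=C1O[C@H]([C@@H](O)Cn2cc(-c3cc(F)cc(F)c3)nn2)C(OCc2ccccc2)=C1OCc1ccccc1` differs from compound 1 by one change: 3,5-difluorophenyl in place of 4-pentylphenyl on an aromatic carbon. Within the data shown here, no measured pair shows this change, so its effect is unknown. The step from compound 1 to compound 4 is expected to weaken inhibition beyond the scatter, a 2.4-fold higher number from compound 1 to compound 4 (0.38 log units; beyond the scatter). Compound 4 is estimated at 20000 nM, between 5000 nM and 100000 nM.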

Compound 4, half-maximal inhibitory concentration: 40800 nM
The estimate for compound 4 lay 2.0-fold (0.31 log units) below the measured number; the range from low to high includes it.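

This position responds to what it carries: in this assay, 3,5-difluorophenyl in place of 4-pentylphenyl gives a 4.9-fold higher number from compound 1 to compound 4 (0.69 log units; beyond the scatter). The core of compound 1 stays the same, so this single swap accounts for the step, and compound 4 still gives a measured number. Compound 2 and compound 3 each stop at a limit, not a number, and neither differs from compound 1 in one place only: the limit of > 100000 nM in this assay, at which 2 of the 4 values shown sit.

As far as these compounds go, the swap removes the pentyl chain and adds the two fluorines at once, so which of them matters stays open. An unsubstituted phenyl or a 4-octylphenyl on this carbon would help separate the two.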